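The compounds below may be only part of what the source reports. "The series", "measured", "known", "first", "only" and "open" are said of these compounds alone.

Compounds measured so far:
- compound 1, `Nc1nc(N)c2cc(CSC(=S)N3CCN(c4ccccc4)CC3)ccc2n1`: 2840 nM
- compound 2, `Nc1nc(N)c2cc(CSC(=S)N3CCN(c4ccccc4Cl)CC3)ccc2n1`: 4050 nM
- compound 3, `Nc1nc(N)c2cc(CSC(=S)N3CCN(c4ccccc4[N+](=O)[O-])CC3)ccc2n1`: 4880 nM

All three share one core and differ only in what sits on the aromatic ring at the far end. They were tested in a functional assay on HeLa cells (Homo sapiens) for antiproliferative activity, read by MTT assay, with a stated time of 72 h; on this read-out lower numbers stand for stronger inhibition and higher numbers for weaker inhibition. Compound 1 sits at the low end of the three numbers, yet neither a 1.4-fold higher number from compound 1 to compound 2 (0.15 log units; within the scatter) nor a 1.7-fold higher number from compound 1 to compound 3 (0.24 log units; within the scatter) reaches beyond the usual scatter, and a 1.2-fold higher number from compound 2 to compound 3 (0.08 log units; within the scatter) is also within it, so the three cannot really be told apart.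

Compound 4, `Nc1nc(N)c2cc(CSC(=S)N3CCN(c4ncccn4)CC3)ccc2n1`, is not yet measured. It differs from compound 1 in one place: pyrimidin-2-yl in place of phenyl on an amine nitrogen in a ring. Within the data shown here, none of the measured steps swaps the whole ring, so no step bears on this change directly. What they do show is that small changes at this end of the molecule, chloro or nitro in place of hydrogen, left this assay unmoved beyond the scatter. On that basis no step beyond the scatter is expected here either, in either direction.

Compound 4 is therefore expected to give about 3500 nM, with a range from 1500 nM to 9000 nM, which amounts to an expected step of a 1.2-fold higher number from compound 1 to compound 4 (0.09 log units; within the scatter).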

Compound 4, half-maximal inhibitory concentration: 4360 nM
Estimate against measurement, compound 4: 1.2-fold (0.10 log units) below; measured number inside the range.
By their numbers in this assay, from the lowest: compounds 1, 2, 4 and 3 (each within the scatter of the next).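

Swapping the whole phenyl ring for pyrimidin-2-yl, which takes this end from 0 to 2 hydrogen-bond acceptors, still leaves this assay without a change beyond the scatter, with a 1.5-fold higher number from compound 1 to compound 4 (0.19 log units; within the scatter) for this exchange. The new ring also stays within the scatter of both substituted rings, with a 1.1-fold higher number from compound 2 to compound 4 (0.03 log units; within the scatter) and a 1.1-fold lower number from compound 3 to compound 4 (0.05 log units; within the scatter) as the two steps, so among these four compounds the insensitivity seen for chloro and nitro now extends to replacing the ring itself. No measurement at hand explains why these numbers stay so close.

All four compounds carry a six-membered aromatic ring on this amine nitrogen, so a benzyl group, a saturated cyclohexyl ring or a plain methyl there remains untested in what is shown. Equally open, on these data alone, is whether a carboxylic acid or an amine on the far ring would move the number beyond the scatter.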